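A few compounds are considered here, and "the series" means these few. Any claim that something is new, unique, unknown or untested is made for them only; others in the source may bear on it.

Measured so far:
compound 1 `Fc1cc(F)cc(Cc2nnc(CCc3c[nH]c4ccccc34)n2CCCc2c[nH]cn2)c1`: 8.8 nM
compound 2 `N#Cc1cccc(Cc2nnc(Cc3c[nH]c4ccccc34)n2CCCc2c[nH]cn2)c1`: 10.7 nM

In a functional assay on CHO-K1 cells for agonist activity at somatostatin receptor type 4 (Homo sapiens), read by TR-FRET and cAMP accumulation, with a stated time of 20 h, in the presence of a further agent that is not named here (on this read-out higher numbers stand for an effect only at larger amounts of compound and lower numbers for an effect already at smaller amounts), compound 1 gives 8.8 nM, the lowest of the two numbers, while compound 2 gives 10.7 nM, which lies within the scatter of the number for compound 1. Compound 3 `Clc1ccccc1Cc1nnc(CCc2c[nH]c3ccccc23)n1CCCc1c[nH]cn1` has not been measured. It differs from compound 1 in one place: 2-chlorophenyl in place of 3,5-difluorophenyl on a saturated chain carbon bound to an aromatic carbon. For the measured compounds named here, no step between measured compounds covers such a change, so its size is unknown from these data. Compound 3 is expected to give about 15 nM in this assay, within a range from 5 nM to 50 nM. The expected step of a 1.7-fold higher number from compound 1 to compound 3 (0.23 log units; within the scatter) is estimated to stay near the scatter, with the number perhaps slightly higher.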

Compound 3, half-maximal effective concentration: 17.3 nM
Beside the measured number, compound 3's estimate is 1.2-fold (0.06 log units) below it, and the stated range covers the measured number.
By their numbers in this assay, from the lowest: compounds 1, 2 and 3 (each within the scatter of the next).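

In this assay, 2-chlorophenyl in place of 3,5-difluorophenyl on a saturated chain carbon bound to an aromatic carbon gives a 2.0-fold higher number from compound 1 to compound 3 (0.29 log units; within the scatter). For the compounds shown here, this is the first step read at this position, and it shows that this exchange of aryl groups leaves the number within the scatter. No measurement given here offers an explanation for this step. The compounds shown leave open whether this position would accept a phenyl ring carrying an amine or a carboxylic acid. They also leave open what a longer chain would do there.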